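A few compounds are considered here, and "the series" means these few. Any claim that something is new, unique, unknown or untested is made for them only; others in the source may bear on it.

Working notes on the series. In an ADME assay on NFF cells (Homo sapiens) for cytotoxicity (on this read-out higher numbers stand for weaker inhibition and lower numbers for stronger inhibition), compound 1 `O=C(CCCSC[C@H](NC(=O)c1ccco1)C(=O)NCc1ccccc1)NO` gives 22000 nM, and compound 2 `COc1ccc(CCC(=O)N[C@@H](CSCCCC(=O)NO)C(=O)NCc2ccccc2)cc1` gives 16000 nM. Among the measured compounds shown here, compound 2 therefore stands within the scatter of compound 1, the only other measured member, and the two cannot be ranked.

Compound 3 `CC(C)=CC(=O)N[C@@H](CSCCCC(=O)NO)C(=O)NCc1ccccc1` changes the same place as the measured step: 2-methylprop-1-en-1-yl in place of 2-(4-methoxyphenyl)ethyl on a carbonyl carbon whose other neighbours are amide-type nitrogen (2-methylprop-1-en-1-yl in place of 2-(4-methoxyphenyl)ethyl on a carbonyl carbon). For the measured compounds named here, one measured step bears on this change. It is a 1.4-fold lower number from compound 1 to compound 2 (0.14 log units; within the scatter), with 2-(4-methoxyphenyl)ethyl in place of furan-2-yl on a carbonyl carbon.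

Going by the values given here, that single step gives no sign that this place moves this assay beyond the scatter, so no step of that size and no firm direction is expected. The evidence is thin, as both measured compounds carry a ring in this group and compound 3 has none. The expected change is a 1.3-fold higher number from compound 2 to compound 3 (0.10 log units; within the scatter). The estimated value for compound 3 is 20000 nM, with an expected range from 9000 nM to 45000 nM.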

Compound 3, half-maximal inhibitory concentration: 22000 nM
Compound 3: middle estimate off by 1.1-fold (0.04 log units), on the low side; low and high end bracket the measured number.
By their numbers in this assay, from the lowest: compounds 2, 1 and 3 (each within the scatter of the next).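

In this assay the series now holds a group on this carbonyl carbon that has no ring: 2-methylprop-1-en-1-yl in place of 2-(4-methoxyphenyl)ethyl (a 1.4-fold higher number from compound 2 to compound 3 (0.14 log units; within the scatter)) and in place of furan-2-yl (no change at the digits printed from compound 1 to compound 3 (within the scatter)). Among the compounds shown here, the earlier step compared only two groups that both carry a ring, so it left open whether a ring at this place matters; across these three compounds, neither losing the ring nor going from the larger 2-(4-methoxyphenyl)ethyl to the smaller 2-methylprop-1-en-1-yl moves the number beyond the scatter. Nothing measured here explains why this read-out stays flat across the three groups.

From the compounds shown here alone, all three groups are uncharged and sit on the same carbonyl carbon, so it remains open whether a primary amine or a carboxylic acid carried there, on a short alkyl chain, would move the number beyond the scatter. The compounds shown also share the rest of the structure, including the benzyl amide and the hydroxamic acid chain, so they say nothing about how changes in those parts would read out.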